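The source may report more compounds than this note shows. Statements on the series, on what has been measured and on what is new or still open speak of the compounds shown alone.

Compound 1, `O=C1CC(c2ccc(F)cc2)Nc2c(Br)cc(Br)cc21`, gives > 100000 nM in a functional assay on MCF7 cells (Homo sapiens) for cytotoxicity, read by sulforhodamine B assay, with a stated time of 48 h (on this read-out lower numbers stand for higher toxicity in this test and higher numbers for lower toxicity in this test), which is a limit of the test and not a number.
Compound 2, `O=C1CC(c2ccc([N+](=O)[O-])cc2)Nc2c(Br)cc(Br)cc21`, gives > 100000 nM in this assay, again a limit.
Compound 3, `O=C1CC(c2cccc(O)c2)Nc2c(Br)cc(Br)cc21`, gives > 100000 nM in this assay, also a limit.

Compound 2 thus stands on a limit, and the two further values shown beside it are limits as well. The step from compound 1 to compound 2, nitro in place of fluoro on an aromatic carbon, is a step that the two limits leave unreadable from compound 1 to compound 2. This account follows the move from compound 2 to compound 4, `CN(C)c1ccc(C2CC(=O)c3cc(Br)cc(Br)c3N2)cc1`, which is not yet measured in this assay. The change is dimethylamino in place of nitro on an aromatic carbon, placed on a six-membered aromatic ring of carbon only, para to a large group. For the measured compounds named here, only one measured step touches this position, and its size cannot be read. What the record does show is the limit of > 100000 nM in this assay, at which 3 of the 3 values shown sit, so every value gathered so far sits at the same limit. With no readable step at this position, the estimate for compound 4 in this assay is 150000 nM, spanning 50000 nM to 500000 nM, which amounts to an expected step that the limit leaves unreadable from compound 2 to compound 4, with a high chance that only a limit is reported.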

Compound 4, concentration lethal to 50% of the cells: > 100000 nM
Compound 4 ended at the assay's limit; the forecaster's own chance of this, stated with the estimate: 70%; the middle value lies beyond the limit too.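

Compound 4 gives > 100000 nM in this assay, which is again a limit and not a number. No new step can be read, since the steps linking compound 4 to compound 1 and compound 2 each join two limits. The compounds shown leave open how large these steps are and whether any aromatic substituent would give a readable value, for the record holds only this: the limit of > 100000 nM in this assay, at which 4 of the 4 values shown sit.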